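The source may report more compounds than this note shows. Statements on the series, on what has been measured and on what is new or still open speak of the compounds shown alone.

Three related compounds have so far been measured in a physicochemical assay, read by spectrophotometry, with a stated time of 6 min; a higher number here means a weaker inhibitor, a lower number a stronger inhibitor. Compound 1, `COc1cc(/C=N/NC(=O)CCc2nc3ccccc3c(=O)[nH]2)ccc1O`, gives 95000000 nM. Compound 2, `COc1cc(/C=N/NC(=O)CCc2nc3ccccc3c(=O)[nH]2)cc(O)c1O`, differs from it only by hydroxy in place of hydrogen on an aromatic carbon; in this assay compound 2 gives 40000000 nM, so the change made a 2.4-fold lower number from compound 1 to compound 2 (0.38 log units; beyond the scatter). Compound 3, `O=C(CCCc1nc2ccccc2c(=O)[nH]1)N/N=C/c1ccc(O)cc1`, has a different core; the difference between the two cores is not broken down here. In this assay compound 3 gives 170000000 nM, which sits within the scatter of compound 1 and beyond it against compound 2.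

Compound 4, `O=C(CCCc1nc2ccccc2c(=O)[nH]1)N/N=C/c1ccc(O)c(O)c1`, has not yet been measured. It differs from compound 3 by hydroxy in place of hydrogen on an aromatic carbon. This is the same kind of change as that from compound 1 to compound 2, though not the same: in compound 2 the place is also meta to a methoxy group, which is absent in compound 4. A step of similar size is expected, a 2.4-fold lower number from compound 3 to compound 4 (0.39 log units; beyond the scatter), because the earlier step gave a 2.4-fold lower number from compound 1 to compound 2 (0.38 log units; beyond the scatter). On that basis compound 4 is estimated at 70000000 nM in this assay, expected to fall between 35000000 nM and 140000000 nM.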

Compound 4, half-maximal inhibitory concentration: 50000000 nM
Estimate against measurement, compound 4: 1.4-fold (0.15 log units) above, within the range that was stated.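

In this assay, hydroxy in place of hydrogen on an aromatic carbon gave a 3.4-fold lower number from compound 3 to compound 4 (0.53 log units; beyond the scatter) and, on the core of compound 1, the same kind of change gave a 2.4-fold lower number from compound 1 to compound 2 (0.38 log units; beyond the scatter) in the same direction, both steps beyond the scatter. This shows that the change carried over between these two cores in direction, but it rests on one pair per core, so it gives no rule for any further core, and compound 2 also carries a methoxy group that compound 4 lacks. Nothing shown here explains why the added hydroxy lowers the number on either core.

The compounds shown leave open whether an amine or a carboxylic acid in place of this hydroxy would move the number the same way. They also leave open whether the step would hold with a longer chain between the core and the hydrazone carbonyl.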